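Swapping Methoxy for Chloro on the Meta-Substituted Side Ring

This account rests on a few compounds, and the source may have more. Where it says the series, first, only, none or still open, it means among the compounds named here.

Measured compounds:
compound 1 `CCCC(Nc1cncc(-c2ccc(O)c(OC)c2)n1)c1ccc(OC)cc1` gives 3000 nM
compound 2 `CCCC(Nc1cncc(-c2ccc(O)c(OC)c2)n1)c1ccc(Cl)cc1` gives 20000 nM
compound 3 `CCCC(Nc1cncc(-c2ccc(O)c(OC)c2)n1)c1cccc(OC)c1` gives 10000 nM

All three compounds share one core and were tested in a functional assay on PC-3 cells (Homo sapiens) for cytotoxicity, read by MTT assay, with a stated time of 72 h; on this read-out higher numbers stand for weaker inhibition and lower numbers for stronger inhibition; they differ only in the aromatic ring that sits on the saturated chain carbon next to the ring nitrogen. Going from compound 1 to compound 2 gives a 6.7-fold higher number from compound 1 to compound 2 (0.82 log units; beyond the scatter); the change is chloro in place of methoxy on an aromatic carbon. Going from compound 1 to compound 3 gives a 3.3-fold higher number from compound 1 to compound 3 (0.52 log units; beyond the scatter); here the change is 3-methoxyphenyl in place of 4-methoxyphenyl on a saturated chain carbon bound to a nitrogen on an aromatic ring and a saturated chain carbon. Compound 2 and compound 3 lie close to each other: a 2.0-fold lower number from compound 2 to compound 3 (0.30 log units; within the scatter).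

Compound 4 `CCCC(Nc1cncc(-c2ccc(O)c(OC)c2)n1)c1cccc(Cl)c1` has not yet been measured in this assay. It is related to compound 3 by chloro in place of methoxy on an aromatic carbon. This is the same kind of change as the one from compound 1 to compound 2, but not the same: there the place was para to a large group, whereas here it is meta to a large group, and the two cores differ as described above. The earlier instance of this change gave a 6.7-fold higher number from compound 1 to compound 2 (0.82 log units; beyond the scatter). On that basis, and allowing for the different place, the step for compound 4 is expected to be a 4.0-fold higher number from compound 3 to compound 4 (0.60 log units; beyond the scatter). The estimate for compound 4 is 40000 nM, with a likely range from 12000 nM to 150000 nM.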

Compound 4, half-maximal inhibitory concentration: 1000 nM
Beside the measured number, compound 4's estimate is 40-fold (1.60 log units) above it; measured number outside the range, below it.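

In this assay, chloro in place of methoxy gives a 10-fold lower number from compound 3 to compound 4 (1.00 log units; beyond the scatter), so the change that weakened inhibition on the core of compound 1 strengthened it on the core of compound 3, and its direction did not carry over: the same change on two cores in this assay, a 6.7-fold higher number (0.82 log units; beyond the scatter) from compound 1 to compound 2 and a 10-fold lower number (1.00 log units; beyond the scatter) from compound 3 to compound 4, 67-fold (1.82 log units) apart, beyond the scatter of two such steps

The other two steps place compound 4 as the strongest of the four, with a 20-fold lower number from compound 2 to compound 4 (1.30 log units; beyond the scatter) for 3-chlorophenyl in place of 4-chlorophenyl and a 3.0-fold lower number from compound 1 to compound 4 (0.48 log units; beyond the scatter) for 3-chlorophenyl in place of 4-methoxyphenyl. Among these compounds, this shows that the result of swapping methoxy for chloro depends on where the group sits on the side ring, but it rests on only one pair of compounds for each place, in a single cell assay, and it does not show why the direction reverses or whether the reversal would hold on any other core.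

Going by these compounds, it remains open whether the gain seen with compound 4 belongs to chloro alone or would also appear with a bromo, a nitrile or an amine in the same place on the ring. On these data alone, it is also open whether that gain would survive a longer chain on the saturated carbon that carries the side ring.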